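The source may report more compounds than this note shows. Statements on the series, on what has been measured and on what is new or still open speak of the compounds shown alone.

Measured so far:
- compound 1, `CNC[C@@H]1CCCc2cc(S(=O)(=O)c3cc[nH]c3)ccc21`, 0.159 nM
- compound 2, `O=C1CN(C[C@@H]2CCCc3cc(S(=O)(=O)c4cccc(F)c4)ccc32)CCN1`, 6.31 nM

In an assay on isolated protein for displacement of a labelled ligand from 5-hydroxytryptamine receptor 6 (Homo sapiens) (a lower number here means a stronger inhibitor, a higher number a weaker inhibitor), compound 1 gives 0.159 nM. Compound 2 gives 6.31 nM in this assay, the higher of the two numbers, and its gap to compound 1 lies beyond the scatter. Among the compounds with values here, no single-change step between the two measured compounds is available, so the account rests on what their two values show.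

Compound 3, `O=C(CO)NC[C@@H]1CCCc2cc(S(=O)(=O)c3cccc(F)c3)ccc21`, is the next compound to be measured in this assay. It differs from compound 2 in one place: ((hydroxymethyl)carbonyl)amino in place of 3-oxopiperazin-1-yl on a saturated chain carbon bound to a saturated ring carbon.

Because compound 2 already stands at 6.31 nM, the expectation is that compound 3 moves further toward a higher number, by a step of a 6.3-fold higher number from compound 2 to compound 3 (0.80 log units; beyond the scatter), beyond the scatter but not a large one. For compound 3 the estimated value in this assay is 40 nM, with a range from 8 nM to 250 nM.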

Compound 3, inhibition constant: 0.1 nM
The estimate for compound 3 lay 400-fold (2.60 log units) above the measured number; measured number outside the range, below it.
By their numbers in this assay, from the lowest: compounds 3 and 1 (each within the scatter of the next); then compound 2.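

At the saturated chain carbon bound to a saturated ring carbon, the group attached matters a great deal: in this assay, ((hydroxymethyl)carbonyl)amino in place of 3-oxopiperazin-1-yl gives a 63-fold lower number from compound 2 to compound 3 (1.80 log units; beyond the scatter). The six-membered ring of 3-oxopiperazin-1-yl is therefore not required for a low number at this position, since compound 3, whose group has no ring, gives 0.1 nM. Nothing available bears on why the number falls so far.

This one step changes the ring, the size of the group and its hydrogen-bond donors together, so it cannot show which of these differences goes with the lower number. It also leaves open whether an acetylamino group, lacking the hydroxyl, or a simple primary amine would give a similarly low number at this position.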